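Adding One Methoxy to Compound 1

A few compounds are considered here, and "the series" means these few. Any claim that something is new, unique, unknown or untested is made for them only; others in the source may bear on it.

Measured in a functional assay on MDA-MB-231 cells (Homo sapiens) for inhibition, read by MTT assay, with a stated time of 48 h; on this read-out lower numbers stand for stronger inhibition and higher numbers for weaker inhibition:
- compound 1 `COc1cc(C2=NOC(c3c[nH]c4ccccc34)C2)cc(OC)c1OC`: 11700 nM
- compound 2 `COc1ccc(C2=NOC(c3c[nH]c4ccccc34)C2)cc1OC`: > 100000 nM (a limit of the assay, not a number)

Among the compounds with values here, compound 1 holds the only true number in this small set. The result for compound 2 is the limit of > 100000 nM in this assay, at which 1 of the 2 values shown sits. Compound 3 `COc1ccc2[nH]cc(C3CC(c4cc(OC)c(OC)c(OC)c4)=NO3)c2c1` is still unmeasured in this assay. It differs from compound 1 by methoxy in place of hydrogen on an aromatic carbon. Within the data shown here, the only measured step is an at least 8.5-fold higher number from compound 1 to compound 2 (0.93 log units; beyond the scatter), with hydrogen in place of methoxy on an aromatic carbon. That step lies beyond the scatter, but it concerns another part of the molecule and ends at a limit, so it gives only a loose guide. No step beyond the scatter is therefore expected, in either direction, and the expected step is a 1.2-fold lower number from compound 1 to compound 3 (0.07 log units; within the scatter). For compound 3 the estimated value is 10000 nM, with an expected range from 3000 nM to 40000 nM.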

Compound 3, half-maximal inhibitory concentration: 26000 nM
For compound 3 the middle estimate is 2.6-fold (0.41 log units) below the measured one, and the stated range covers the measured number.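

In this assay, methoxy in place of hydrogen on an aromatic carbon of the six-membered aromatic ring of carbon only gives a 2.2-fold higher number from compound 1 to compound 3 (0.35 log units; beyond the scatter), so this position of the fused system of two rings does respond to the change. Unlike the earlier step, which ends at a limit, this one ends at a true number, so its size can be read, and compound 3 remains measurable in this assay despite being weaker than compound 1. Nothing given here accounts for this step.

Within the data shown here, only this one group appears at this position, so it stays open whether a hydroxyl, a chlorine or an amine on the same carbon would shift the number in the same direction. As far as these compounds go, it also stays open what this methoxy would do on compound 2, whose result is a limit.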